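The source may report more compounds than this note shows. Statements on the series, on what has been measured and on what is new or still open speak of the compounds shown alone.

Working notes on the glucose-derived ketone series.

Three compounds carry a number in an assay for inhibition of glucose-6-phosphatase catalytic subunit 1 (Rattus norvegicus), tested at 100 uM; a lower number here means less inhibition, a higher number more inhibition at the concentration tested (going by the name of the read-out). Compound 1 `O=C(/C=C/c1ccccc1)C[C@@H]1O[C@H](CO)[C@@H](O[C@@H]2O[C@H](CO)[C@@H](O)[C@H](O)[C@H]2O)[C@H](O)[C@H]1O` gives -16.3% in this assay. Compound 3 `COc1cc(/C=C/C(=O)C[C@@H]2O[C@H](CO)[C@@H](O)[C@H](O)[C@H]2O)cc(OC)c1OC` gives 4.7% in this assay. Compound 2 `CCOC(=O)C(C(=O)OCC)C(CC(=O)C[C@@H]1O[C@H](CO)[C@@H](O)[C@H](O)[C@H]1O)c1ccc(Cl)cc1` gives -6% in this assay, which places it second highest of the three: compound 1 sits lower by a margin beyond the scatter, and compound 3 sits higher by a margin beyond the scatter. All three numbers cluster near zero, so none of the compounds shows appreciable inhibition at the concentration tested.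

Compound 4 `CCOC(=O)C(C(=O)OCC)C(CC(=O)C[C@@H]1O[C@H](CO)[C@@H](O)[C@H](O)[C@H]1O)c1cccnc1` has not yet been measured in this assay. It differs from compound 2 in one place (pyridin-3-yl in place of 4-chlorophenyl on a saturated chain carbon bound to two saturated chain carbons). Going by the values given here, no pair of measured compounds differing in one place is available, so the size of this change is untested. Given that every measured value stays close to zero, the step is expected to be none beyond the scatter, a number 2 percentage points higher from compound 2 to compound 4 (within the scatter). Compound 4 is thus estimated at -4%, with a range from -18% to 11%.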

Compound 4, a percentage reported as inhibition, at one concentration (the size of the read-out at that concentration, not a potency): 37.6%
Compound 4: middle estimate off by 41.6 percentage points, on the low side; measured number above the stated range.
By their numbers in this assay, from the lowest: compound 1; then compound 2; then compound 3; then compound 4.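

The position on the saturated chain carbon bound to two saturated chain carbons now has its first measured single change, and in this assay it responds strongly, with pyridin-3-yl in place of 4-chlorophenyl giving a number 43.6 percentage points higher from compound 2 to compound 4 (beyond the scatter) on an otherwise unchanged structure. The earlier numbers gave no sign that the series could move this far, so this position cannot be treated as indifferent to the group it carries. Nothing at hand accounts for the size of this step, and it stands as an observation only.

Still open, as far as these compounds go, is whether the step follows from gaining the ring nitrogen or from losing the chlorine, a question that a plain phenyl at this position would address. Equally open, from the compounds shown here alone, is whether pyridin-4-yl or pyridin-2-yl would match pyridin-3-yl here, and whether the same exchange holds on the other structures.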